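Swapping the biaryl for a phenethyl chain

The source may report more compounds than this note shows. Statements on the series, on what has been measured and on what is new or still open speak of the compounds shown alone.

Three compounds share one core, a long-chain sulfonamide on a benzoic acid, and differ only in the group attached to the ring. In an assay on mitochondria (strain BALB/c) for inhibition of glycerol-3-phosphate acyltransferase 1, mitochondrial (Mus musculus), read by scintillation counting, with a stated time of 10 min (a higher number here means a weaker inhibitor, a lower number a stronger inhibitor), compound 1, `CCCCCCCCS(=O)(=O)Nc1cc(-c2ccc(OC)cc2)ccc1C(=O)O`, gives 13300 nM. Compound 2, `CCCCCCCCS(=O)(=O)Nc1cc(-c2cccc(F)c2)ccc1C(=O)O`, gives 32600 nM in this assay. Compound 3, `CCCCCCCCS(=O)(=O)Nc1cc(-c2ccc(O)cc2)ccc1C(=O)O`, gives 64800 nM in this assay, the highest of the three numbers; its gap to compound 2 lies within the scatter, while the step of a 4.9-fold higher number from compound 1 to compound 3 (0.69 log units; beyond the scatter) lies beyond it.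

Compound 4, `CCCCCCCCS(=O)(=O)Nc1cc(CCc2ccccc2)ccc1C(=O)O`, is not yet measured. The change is phenethyl in place of 4-hydroxyphenyl on an aromatic carbon; it sits meta to a large group and para to a carboxy group.

Among the compounds with values here, no measured step covers a phenethyl group, so the expectation rests on indirect hints. The step of a 4.9-fold higher number from compound 1 to compound 3 (0.69 log units; beyond the scatter) shows that adding a hydrogen-bond donor at this position gave a clearly higher number, and the step of a 2.0-fold higher number from compound 2 to compound 3 (0.30 log units; within the scatter) stayed within the scatter. Since compound 4 carries no donor and no acceptor, a modest lower number than compound 3 is expected, though with wide uncertainty. The expected step is a 2.2-fold lower number from compound 3 to compound 4 (0.33 log units; beyond the scatter). Compound 4 is therefore estimated at 30000 nM in this assay, with a range from 8000 nM to 100000 nM.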

Compound 4, half-maximal inhibitory concentration: 37500 nM
For compound 4 the middle estimate is 1.3-fold (0.10 log units) below the measured one, within the range that was stated.
By their numbers in this assay, from the lowest: compound 1; then compounds 2, 4 and 3 (each within the scatter of the next).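

Phenethyl is the first group here whose aromatic ring is not joined directly to the core, and in this assay that change leaves no readable mark, with a 1.7-fold lower number from compound 3 to compound 4 (0.24 log units; within the scatter) and a 1.2-fold higher number from compound 2 to compound 4 (0.06 log units; within the scatter) both small. Compound 4 has no hydrogen-bond donor or acceptor in this group, while the 4-hydroxyphenyl of compound 3 has one of each, so removing them together with adding the chain produces no shift that can be separated from ordinary assay variation. Within the data shown here, the 4-methoxyphenyl of compound 1 remains the one group that stands apart, as a 2.8-fold higher number from compound 1 to compound 4 (0.45 log units; beyond the scatter) shows, and the data give no measured explanation for that difference.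

From the compounds shown here alone, it remains open whether the length of the link matters, since a benzyl group or a longer chain ending in the same phenyl ring would test this directly. It is also unknown whether a methoxy group placed on the ring of the phenethyl group would bring the number back towards that of compound 1, which would show whether this substituent still counts once the ring sits further from the core.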